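This account rests on a few compounds, and the source may have more. Where it says the series, first, only, none or still open, it means among the compounds named here.

Compound 3 `CCOC(=O)N1CCC(NS(=O)(=O)c2ccc(NCc3ccccc3)c3ccccc23)CC1` stands second highest of the three numbers in an assay on L1.2 cells for binding affinity to C-C chemokine receptor type 8 (Homo sapiens) (a higher number here means a weaker inhibitor, a lower number a stronger inhibitor), where compound 3 gives 45.6 nM. Compound 2 `CCOC(=O)N1CCC(NS(=O)(=O)c2ccc(C(=O)NC3CCCCC3)c3ccccc23)CC1` gives 9.5 nM and compound 1 `O=C(Nc1ccc(S(=O)(=O)N2CCOCC2)c2ccccc12)c1ccccc1` gives 7750 nM. Among the compounds with values here, the one measured step that changes a single place, a 4.8-fold higher number from compound 2 to compound 3 (0.68 log units; beyond the scatter), is modest. Compound 4 `CCOC(=O)N1CCC(NS(=O)(=O)c2ccc(NC(=O)N3CCCCC3)c3ccccc23)CC1` differs from compound 3 by (piperidin-1-yl)carbonyl in place of benzyl on a nitrogen on an aromatic ring. That step bears on this change: the entering group again carries a carbonyl, as the cyclohexylcarbamoyl of compound 2 does on an aromatic carbon, whereas compound 3 carries only benzyl there. Within the data shown here, no measured pair spans exactly this exchange. In this assay a move back toward lower numbers is expected, a 2.3-fold lower number from compound 3 to compound 4 (0.36 log units; beyond the scatter). For compound 4 the estimate is 20 nM, within 5 nM to 80 nM.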

Compound 4, inhibition constant: 126 nM
For compound 4 the middle estimate is 6.3-fold (0.80 log units) below the measured one; the whole stated range lies below it.
By their numbers in this assay, from the lowest: compound 2; then compound 3; then compound 4; then compound 1.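

In this assay, (piperidin-1-yl)carbonyl in place of benzyl on a nitrogen on an aromatic ring gives a 2.8-fold higher number from compound 3 to compound 4 (0.44 log units; beyond the scatter), so a carbonyl entering at this nitrogen does not move the series back toward lower numbers. Measured against cyclohexylcarbamoyl, the same carbonyl-bearing group gives a 13-fold higher number from compound 2 to compound 4 (1.12 log units; beyond the scatter), a large step, so a carbonyl present in both groups does not by itself preserve the low number of compound 2. Nothing at hand explains either step. Still open, going by these compounds, is how acetyl or methyl on the same nitrogen would compare with benzyl, and how a carboxylic acid on that aromatic carbon would compare with cyclohexylcarbamoyl.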